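The source may hold more compounds than are shown below. What is called first, only, known or untested is meant among the compounds shown, and "the series" means these compounds.

Three compounds have been measured in a functional assay on cells (T-cell, Homo sapiens) for inhibition; on this read-out lower numbers stand for stronger inhibition and higher numbers for weaker inhibition:

Compound 1 `COc1ccc(-c2cnc3nc(N)nc(N4CCN(C(=O)Nc5ccc(C)cc5)CC4)c3n2)cc1OC`: 0.8 nM
Compound 2 `COc1ccc(-c2cnc3nc(N)nc(N4CCN(Cc5ccccc5)CC4)c3n2)cc1OC`: 900 nM
Compound 3 `COc1ccc(-c2cnc3nc(N)nc(N4CCN(C(=O)Nc5ccccc5)CC4)c3n2)cc1OC`: 3.4 nM

All three share one core and differ only in the group carried on an amine nitrogen in a ring. Compound 3 stands second highest of the three numbers. Its nearest neighbour is compound 1, which gives a lower number: a 4.3-fold higher number from compound 1 to compound 3 (0.63 log units; beyond the scatter). Its furthest neighbour is compound 2: a 260-fold lower number from compound 2 to compound 3 (2.42 log units; beyond the scatter).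

Compound 4 `COc1ccc(-c2cnc3nc(N)nc(N4CCN(c5ccccc5)CC4)c3n2)cc1OC` has not been measured. It differs from compound 3 in one place: phenyl in place of phenylcarbamoyl on an amine nitrogen in a ring.

Going by the values given here, two measured steps bear on this change, since both exchange a carbamoyl-type group on the same ring nitrogen for a group without it: a 1100-fold higher number from compound 1 to compound 2 (3.05 log units; beyond the scatter) and a 260-fold lower number from compound 2 to compound 3 (2.42 log units; beyond the scatter). Both are large, and both point the same way: the number rises steeply whenever the carbamoyl group is lost. Among the compounds with values here, no measured pair swaps a carbamoyl group for a plain phenyl, so the expectation rests on this likeness alone and is less sure than it would otherwise be. A large rise in the number is nevertheless expected: an 88-fold higher number from compound 3 to compound 4 (1.95 log units; beyond the scatter). For compound 4 the estimate in this assay is 300 nM, with a range from 30 nM to 3000 nM.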

Compound 4, half-maximal inhibitory concentration: 400 nM
Compound 4: middle estimate off by 1.3-fold (0.12 log units), on the low side; low and high end bracket the measured number.
By their numbers in this assay, from the lowest: compound 1; then compound 3; then compound 4; then compound 2.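

In this assay, taking away the carbonyl and its amide nitrogen while keeping the phenyl ring on the amine nitrogen gives a 120-fold higher number from compound 3 to compound 4 (2.07 log units; beyond the scatter), and the comparison with the methyl-bearing compound gives a 500-fold higher number from compound 1 to compound 4 (2.70 log units; beyond the scatter), so among these four compounds a phenyl ring alone does not bring the low numbers seen with the carbamoyl groups. Compared with the benzyl group, phenyl gives only a 2.3-fold lower number from compound 2 to compound 4 (0.35 log units; beyond the scatter); this step lies beyond the scatter but is small beside the loss of the carbamoyl group, and compound 2 and compound 4 both stay far above compound 1 and compound 3. No evidence is available on what lies behind these differences.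

As far as these compounds go, it remains open whether the carbonyl alone would keep the low numbers, as a benzoyl group on the same nitrogen would test, or whether the amide hydrogen is needed too, as a methyl on the amide nitrogen would test. Also open, from the compounds shown here alone, is how groups other than methyl on the outer phenyl ring, such as methoxy or chlorine, would behave.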